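The source may report more compounds than this note shows. Statements on the series, on what has been measured and on what is new or still open speak of the compounds shown alone.

Measured in an assay on striatum for inhibition of 5-hydroxytryptamine receptor 4 (Cavia porcellus), read by radioligand binding; a lower number here means a stronger inhibitor, a higher number a weaker inhibitor:
compound 1 `COc1cc(N)c(Cl)cc1C(=O)NC1CCN(CC2CCN(C(=O)CN)CC2)CC1`, 9.3 nM;
compound 2 `COc1cc(N)c(Cl)cc1C(=O)NC1CCN(CC2CCN(C(=O)C(C)N)CC2)CC1`, 5.06 nM;
compound 3 `COc1cc(N)c(Cl)cc1C(=O)NC1CCN(CC2CCN(CCCCN)CC2)CC1`, 6.47 nM.

Compound 1 gives the highest of these three numbers, yet all three sit within the scatter of one another: a 1.8-fold lower number from compound 1 to compound 2 (0.26 log units; within the scatter) and a 1.4-fold lower number from compound 1 to compound 3 (0.16 log units; within the scatter), and between compounds 2 and 3 a 1.3-fold higher number from compound 2 to compound 3 (0.11 log units; within the scatter).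

Compound 4 `COc1cc(N)c(Cl)cc1C(=O)NC1CCN(CC2CCN(CC(O)CN)CC2)CC1` differs from compound 1 only at the tail: 3-amino-2-hydroxypropyl in place of (aminomethyl)carbonyl on an amine nitrogen in a ring. The closest guide is the step in which the same (aminomethyl)carbonyl gave way to 4-aminobutyl, a 1.4-fold lower number from compound 1 to compound 3 (0.16 log units; within the scatter), which stayed within the scatter; the other steps did likewise. A similar outcome is therefore expected for compound 4, with a 1.2-fold lower number from compound 1 to compound 4 (0.07 log units; within the scatter) and no step beyond the scatter. Compound 4 is thus estimated at 8 nM, in the range 3 nM to 25 nM.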

Compound 4, half-maximal inhibitory concentration: 14.4 nM
Compound 4: the middle estimate sits 1.8-fold (0.26 log units) below what was measured, and the stated range covers the measured number.
By their numbers in this assay, from the lowest: compounds 2, 3, 1 and 4 (each within the scatter of the next, the first and the last beyond it).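

Placed on this ring nitrogen, the 3-amino-2-hydroxypropyl tail gives the first gaps here that lie beyond the scatter, both modest: a 2.2-fold higher number from compound 3 to compound 4 (0.35 log units; beyond the scatter) and a 2.8-fold higher number from compound 2 to compound 4 (0.45 log units; beyond the scatter). Its swap for (aminomethyl)carbonyl remains within the scatter, with a 1.5-fold higher number from compound 1 to compound 4 (0.19 log units; within the scatter), so this tail can be told apart from two earlier tails but not from that one. No measurement available here explains these steps.

Still open, from the compounds shown here alone, is how a tail ending in a carboxylic acid, or a longer chain ending in an amine, would read at this position.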